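Working notes: the step from compound 2 to compound 3

The source may report more compounds than this note shows. Statements on the series, on what has been measured and on what is new or still open speak of the compounds shown alone.

Measured in a functional assay on Raji cells (Homo sapiens) for cytotoxicity, with a stated time of 72 h; a higher number here means that more compound is needed for the effect, a lower number that less compound is needed:
- compound 1 `C=C[C@@](C)(/C=C/c1ccc(O)cc1)CCC1OC1(C)C` gives > 22500 nM, a limit
- compound 2 `C=C[C@@](C)(/C=C/c1ccc(O)cc1)CCCO` gives > 26000 nM, a limit

Compound 2 stands at a limit only, and no number is available for it in this assay. Compound 3 `C=C[C@@](C)(/C=C/c1ccc(O)cc1)CC/C=C(C)/C=N/N` carries the change (a group of 6 heavy atoms (4 carbon, 2 nitrogen; no ring) in place of a group of 2 heavy atoms (1 carbon, 1 oxygen; no ring), on a saturated chain carbon, three bonds along the chain from two double-bonded chain carbons). Among the compounds with values here, the sole measured step, a step that the two limits leave unreadable from compound 1 to compound 2, has no readable size, so it supports no expected direction and no expected step beyond the scatter. The expected step, an estimate resting on a limit, is an at least 1.0-fold lower number from compound 2 to compound 3 (0.01 log units; that floor lies within the scatter) in this assay. For compound 3 the expected value is estimated at 25000 nM, range 9000 nM to 50000 nM, and another limit is likely.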

Compound 3, half-maximal effective concentration: > 26000 nM
Compound 3 was reported as a limit (the forecaster's own chance of this, stated with the estimate: 70%); middle value at least 1.0-fold (0.01 log units) from the limit.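

In this assay, within the data shown here, compound 1, compound 2 and compound 3 all stand as limits, so no step among them can be read. The compounds shown leave open whether any group at this chain position gives a measurable value in this assay.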